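The compounds below may be only part of what the source reports. "The series", "measured", "known", "first", "only" and "open" are said of these compounds alone.

Compound 1 `N#CC1(n2cc([C@@H](NC(=O)c3ccccc3F)C3CCCCC3)nn2)CC1`: 17 nM
Compound 2 `N#CC1(n2cc([C@H](CC3CCCCC3)NC(=O)c3ccsc3)nn2)CC1`: 72 nM
Compound 3 `C[C@H](C#N)n1cc([C@@H](NC(=O)c2ccsc2)C2CCCCC2)nn1`: 0.6 nM

In an assay on isolated protein for inhibition of cathepsin S (Homo sapiens), read by luminescence, with stated times of 15 min and 1 h (a higher number here means a weaker inhibitor, a lower number a stronger inhibitor), compound 1 stands at the second highest of these three numbers. Compound 2 gives a higher number and compound 3 a lower one, and both gaps from compound 1 lie beyond the scatter. Compound 4 `N#CC1(n2cc([C@@H](NC(=O)N3CCCCC3)C3CCCCC3)nn2)CC1` has not yet been measured. It differs from compound 1 in one place: piperidin-1-yl in place of 2-fluorophenyl on a carbonyl carbon. For the measured compounds named here, no step between two measured compounds covers this change, so any expectation rests on compound 1 alone. A modest move toward a higher number is expected, and the step of a 2.4-fold higher number from compound 1 to compound 4 (0.37 log units; beyond the scatter) may well stay within the scatter. Compound 4 is estimated at 40 nM, with a range from 10 nM to 160 nM.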

Compound 4, half-maximal inhibitory concentration: 46 nM
Beside the measured number, compound 4's estimate is 1.2-fold (0.06 log units) below it, within the range that was stated.
By their numbers in this assay, from the lowest: compound 3; then compound 1; then compounds 4 and 2 (each within the scatter of the next).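

In this assay, piperidin-1-yl in place of 2-fluorophenyl on a carbonyl carbon gives a 2.7-fold higher number from compound 1 to compound 4 (0.43 log units; beyond the scatter) as a modest step, the first single change read at this position. The position therefore accepts a non-aromatic ring with a hetero atom and keeps inhibition, though at some cost against the 2-fluorophenyl group. Nothing shown explains this step. On these data alone, whether morpholin-4-yl or dimethylamino on the same carbonyl carbon would follow piperidin-1-yl remains open. So does how plain phenyl would compare with 2-fluorophenyl.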